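Swapping a methylpyrazole for a dimethylamide on the pyridine

The compounds below may be only part of what the source reports. "The series", "measured", "known", "first", "only" and "open" are said of these compounds alone.

Measured so far:
compound 1, `CCOC(=O)c1cc(C)cc(NNC(=O)Nc2cc(Cl)nc(Cl)c2)n1`, 760 nM
compound 2, `Cc1cc(NNC(=O)Nc2cc(Cl)nc(Cl)c2)nc(-c2cnn(C)c2)c1`, > 2100 nM

Of the compounds shown here, two have been tested in a functional assay on CHO cells for antagonist activity at sphingosine 1-phosphate receptor 2 (Homo sapiens), read by fluorescence and calcium flux, with a stated time of 3 min; a lower number here means a stronger inhibitor, a higher number a weaker inhibitor. Compound 1 `CCOC(=O)c1cc(C)cc(NNC(=O)Nc2cc(Cl)nc(Cl)c2)n1` gives 760 nM. Compound 2 `Cc1cc(NNC(=O)Nc2cc(Cl)nc(Cl)c2)nc(-c2cnn(C)c2)c1` gives only > 2100 nM, which is a limit of the assay rather than a number, so compound 2 stands at the weaker end of the pair (the limit of > 2100 nM in this assay, at which 1 of the 2 values shown sits). Going by the values given here, the single measured step, an at least 2.7-fold higher number from compound 1 to compound 2 (0.44 log units; beyond the scatter), shows that the ethoxycarbonyl group of compound 1 is clearly preferred over the 1-methyl-1H-pyrazol-4-yl group of compound 2.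

Compound 3 `Cc1cc(NNC(=O)Nc2cc(Cl)nc(Cl)c2)nc(C(=O)N(C)C)c1` differs from compound 2 by dimethylcarbamoyl in place of 1-methyl-1H-pyrazol-4-yl on an aromatic carbon. The dimethylcarbamoyl group resembles the ethoxycarbonyl of compound 1 more closely than the 1-methyl-1H-pyrazol-4-yl does, so a return toward the value of compound 1 is expected, though the starting point of compound 2 is only a limit and the expected step of an at least 1.7-fold lower number from compound 2 to compound 3 (0.24 log units; that floor lies within the scatter) is therefore uncertain in size. Compound 3 is estimated at 1200 nM, with a range from 400 nM to 4000 nM.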

Compound 3, half-maximal inhibitory concentration: > 19000 nM
Compound 3 ended at the assay's limit (the forecaster's own chance of this, stated with the estimate: 35%); middle value at least 15-fold (1.19 log units) away from the limit.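

In this assay, dimethylamino in place of ethoxy on the carbonyl carbon gives an at least 25-fold higher number from compound 1 to compound 3 (1.39 log units; beyond the scatter), so keeping a carbonyl next to the ring nitrogen is not enough to hold the activity of compound 1, and what is attached to that carbonyl matters a great deal. Compound 3 gives > 19000 nM, which is a limit of the assay and not a number. Compound 2 gives > 2100 nM, also a limit, so the step between these two compounds cannot be read, and the dimethylcarbamoyl and 1-methyl-1H-pyrazol-4-yl groups cannot be ranked against each other.

Among the compounds shown, only the ethoxycarbonyl group of compound 1 gives a measured number at this position, so a single data point carries all that is known of what this position tolerates. Going by these compounds, whether a smaller ester such as methoxycarbonyl, a longer ester chain, a carboxylic acid or an amide with a hydrogen left on its nitrogen, such as methylcarbamoyl, would match or improve on the ethoxycarbonyl group remains open.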